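A Trifluoromethyl Group on Compound 1

This account rests on a few compounds, and the source may have more. Where it says the series, first, only, none or still open, it means among the compounds named here.

For the measured compounds named here, in a physicochemical assay for lipophilicity, read by LC-MS, using the shake flask method, in phosphate buffer, measured as octanol-water partition, with a stated time of 2 h, at pH 7.4 (on this read-out higher numbers stand for higher lipophilicity and lower numbers for lower lipophilicity), compound 1 `OC[C@H]1O[C@H](n2cc(-c3ccccc3)nn2)[C@@H](O)[C@@H](O)[C@@H]1O` gives 0.21 and holds the lower of the two numbers measured so far. Compound 2 `OC[C@H]1O[C@H](n2cc(-c3cccc(Cl)c3)nn2)[C@@H](O)[C@@H](O)[C@@H]1O` gives 1.22 and differs from compound 1 in one place, with a chloro in place of hydrogen on an aromatic carbon. The measured change is a number 1.01 log units higher from compound 1 to compound 2 (beyond the scatter) and counts as large.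

Compound 3 `OC[C@H]1O[C@H](n2cc(-c3ccc(C(F)(F)F)cc3)nn2)[C@@H](O)[C@@H](O)[C@@H]1O` has not yet been measured in this assay and differs from compound 1 by a trifluoromethyl in place of hydrogen on an aromatic carbon, para to a large group (trifluoromethyl in place of hydrogen on an aromatic carbon). That large chloro step is the only measured one that bears on this change. Going by the values given here, the only guide is therefore compound 2 at 1.22 and it carries a different group, so the comparison stays loose. An upward step of similar size, beyond the scatter, is still expected, and the estimate is a number 1.04 log units higher from compound 1 to compound 3 (beyond the scatter) on this single piece of evidence. For compound 3 the estimated value is 1.25 with an expected range from 0.85 to 1.65 as the likely span.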

Compound 3, distribution coefficient: 1.45
Estimate against measurement, compound 3: 0.20 log units below; the measured number falls inside the stated range.
By their numbers in this assay, from the lowest: compound 1; then compounds 2 and 3 (each within the scatter of the next).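

In this assay, the step of a number 1.24 log units higher from compound 1 to compound 3 (beyond the scatter) shows that a trifluoromethyl in place of hydrogen on an aromatic carbon, para to a large group, produces a large rise on its own. Compound 1 has now been compared with two single-place changes on the six-membered aromatic ring, the chloro of compound 2 and the trifluoromethyl of compound 3, and both give a number beyond the scatter above that of compound 1, with neither compound going against this pattern. The result describes only the size and direction of this one change, and nothing measured here accounts for why the number moves as it does.

The compounds shown leave open whether an amine or a carboxylic acid on this same aromatic carbon would move the number up, down or hardly at all, since every replacement seen so far is a single chloro or trifluoromethyl group. They also leave open whether a trifluoromethyl on another carbon of the ring would give a step of similar size, and whether a chloro para to the large group would match the step seen here.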